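From 4-hydroxyphenyl to 3,4-dimethoxyphenyl on a shared core

The compounds below may be only part of what the source reports. "The series", "measured", "known", "first", "only" and "open" are said of these compounds alone.

Of the compounds shown here, three sharing one core have been measured in a functional assay on HeLa cells (Homo sapiens) for antiproliferative activity, read by MTT assay, with a stated time of 48 h; a lower number here means a stronger inhibitor of growth, a higher number a weaker inhibitor of growth. Compound 1 `COC(=O)N1N=C(c2cccc(C)c2)CC1c1cc(OC)c(OC)c(OC)c1` gives 50 nM, compound 3 `COC(=O)N1N=C(c2ccc(O)cc2)CC1c1cc(OC)c(OC)c(OC)c1` gives 1140 nM, and compound 2 `COC(=O)N1N=C(c2cc(OC)c(OC)c(OC)c2)CC1c1cc(OC)c(OC)c(OC)c1` gives 5680 nM. Compound 3 therefore holds the middle place among the three numbers, clearly apart from both of the others. The next compound, compound 4 `COC(=O)N1N=C(c2ccc(OC)c(OC)c2)CC1c1cc(OC)c(OC)c(OC)c1`, differs from compound 3 in one place: 3,4-dimethoxyphenyl in place of 4-hydroxyphenyl on a carbon with a double bond to nitrogen. It carries 3,4-dimethoxyphenyl in place of 4-hydroxyphenyl on a carbon with a double bond to nitrogen.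

For the measured compounds named here, only one measured step bears directly on this place: a 23-fold higher number from compound 1 to compound 3 (1.36 log units; beyond the scatter), a large change beyond the scatter, with 4-hydroxyphenyl replacing 3-methylphenyl. It shows that a change here can move the number a long way, but it involves no methoxy group. Compound 2, whose ring at the same place also carries methoxy groups, stands at 5680 nM, a higher number than that of compound 3. Compound 4 is therefore expected to lie between these two, nearer compound 3, with only a small rise that need not exceed the scatter. The estimated step is a 1.6-fold higher number from compound 3 to compound 4 (0.20 log units; within the scatter). For compound 4 the expected value is 1800 nM, with an estimated range from 500 nM to 5000 nM.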

Compound 4, concentration for 50% growth inhibition: 3390 nM
Beside the measured number, compound 4's estimate is 1.9-fold (0.27 log units) below it; low and high end bracket the measured number.
By their numbers in this assay, from the lowest: compound 1; then compound 3; then compounds 4 and 2 (each within the scatter of the next).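

In this assay, a 3.0-fold higher number from compound 3 to compound 4 (0.47 log units; beyond the scatter) shows that this position still responds when one oxygen-bearing ring replaces another, although this modest step is much smaller than the one that separates the 4-hydroxyphenyl ring from the 3-methylphenyl ring. The step with hydrogen in place of methoxy on an aromatic carbon, a 1.7-fold lower number from compound 2 to compound 4 (0.22 log units; within the scatter), stays within the scatter, so compounds 2 and 4 cannot be told apart in this assay. The largest step yet seen at this position is a 68-fold higher number from compound 1 to compound 4 (1.83 log units; beyond the scatter), which leaves the 3,4-dimethoxyphenyl ring of compound 4 far from the 3-methylphenyl ring of compound 1.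

No measurement is at hand that would explain any of these steps. On these data alone, it remains open whether an amine or a carboxylic acid on this ring, or a single methoxy group standing where compound 1 carries its methyl, would bring the number close to that of compound 1, which gives 50 nM.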